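The source may report more compounds than this note shows. Statements on the series, on what has been measured and on what is new or still open speak of the compounds shown alone.

Measured so far:
compound 1 `O=C(/C=C\Nc1ccc(O)cc1)c1cn(-c2ccccc2)nc1-c1ccc(F)cc1` — 16300 nM
compound 2 `O=C(/C=C\Nc1ccc(F)cc1)c1cn(-c2ccccc2)nc1-c1ccc(Cl)cc1` — a limit, > 50000 nM
compound 3 `O=C(/C=C\Nc1ccc(Cl)cc1)c1cn(-c2ccccc2)nc1-c1ccc(Cl)cc1` — 23400 nM

In an ADME assay on HaCaT cells (Homo sapiens) for antiproliferative activity, read by MTT assay, with a stated time of 48 h (on this read-out lower numbers stand for stronger inhibition and higher numbers for weaker inhibition), compound 3 gives 23400 nM, the highest of the two numbers shown. Compound 1 stands nearest with 16300 nM, a gap within the scatter. For compound 2 the assay reports only a limit, > 50000 nM. Compound 4 `O=C(/C=C\Nc1ccc(O)cc1)c1cn(-c2ccccc2)nc1-c1ccc(Cl)cc1` differs from compound 3 by hydroxy in place of chloro on an aromatic carbon. Among the compounds with values here, no measured step makes exactly this exchange. Within the data shown here, the only measured step, an at least 2.1-fold lower number from compound 2 to compound 3 (0.32 log units; beyond the scatter), concerns chloro against fluoro at the same position and so does not bear directly on hydroxy. Among the measured compounds shown here, compound 1 carries the same hydroxy group as compound 4 while differing from it elsewhere; no step between them is tabulated, so one can only note that compound 1 gives 16300 nM, close to compound 3. The expectation for compound 4 is therefore a number near those of compound 1 and compound 3, a step of a 1.3-fold lower number from compound 3 to compound 4 (0.11 log units; within the scatter) that stays within the scatter. Compound 4 is estimated at 18000 nM, between 8000 nM and 45000 nM.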

Compound 4, half-maximal inhibitory concentration: 22600 nM
For compound 4 the middle estimate is 1.3-fold (0.10 log units) below the measured one; the range from low to high includes it.
By their numbers in this assay, from the lowest: compounds 1, 4 and 3 (each within the scatter of the next). At a limit, above all of these: compound 2.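

In this assay, hydroxy in place of chloro on an aromatic carbon gives a 1.0-fold lower number from compound 3 to compound 4 (0.02 log units; within the scatter), so the two groups cannot be told apart at this position, while hydroxy in place of fluoro gives an at least 2.2-fold lower number from compound 2 to compound 4 (0.34 log units; beyond the scatter). That second step starts from a limit, so only its minimum size is known. Chloro in place of fluoro at the other position gives a 1.4-fold higher number from compound 1 to compound 4 (0.14 log units; within the scatter), and this exchange does not read alike on the two cores: the same change on two cores in this assay, an at least 2.1-fold lower number (0.32 log units; beyond the scatter) from compound 2 to compound 3 and a 1.4-fold higher number (0.14 log units; within the scatter) from compound 1 to compound 4, at least 2.9-fold (0.47 log units) apart, beyond the scatter of two such steps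

As far as these compounds go, whether an amine or a methoxy group at this position would read like chloro and hydroxy or like fluoro remains open. How far the true number of compound 2 lies past its limit also remains open: the limit of > 50000 nM in this assay, at which 1 of the 4 values shown sits.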